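Removing the Fluorine from a Biphenyl Sulfonamide Piperidine

A few compounds are considered here, and "the series" means these few. Any claim that something is new, unique, unknown or untested is made for them only; others in the source may bear on it.

Of the compounds shown here, three built on a shared sulfonyl-piperidine core have been measured in a functional assay on DLD-1 cells (Homo sapiens) for antiproliferative activity, read by CellTiter-Glo, with a stated time of 72 h; a lower number here means a stronger inhibitor, a higher number a weaker inhibitor. Compound 1 `CC1CCN(C2CCN(S(=O)(=O)c3cccc(-c4ccccc4F)c3)CC2)CC1` gives 10 nM, the lowest of the two numbers recorded. Compound 3 `Cc1cc(C)c(S(=O)(=O)N2CCC(N3CC(C)CC(C)C3)CC2)c(C)c1` gives 17 nM in this assay, and the gap from compound 1 to compound 3 lies within the usual scatter, so the two cannot be ranked against each other. Compound 2 `Cc1cc(C)c(S(=O)(=O)N2CCC(N3CCC(CCC#N)CC3)CC2)c(C)c1` sits at the limit of > 5000 nM in this assay, at which 1 of the 3 values shown sits, and returns > 5000 nM, which is a limit of the assay and not a number.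

Compound 4 `CC1CCN(C2CCN(S(=O)(=O)c3cccc(-c4ccccc4)c3)CC2)CC1` is the next compound to be measured. It differs from compound 1 in a single place: hydrogen in place of fluoro on an aromatic carbon. Cut one bond further out, the change reads 2-fluorophenyl to phenyl. For the measured compounds named here, no pair of measured compounds shows this kind of step, so the expectation rests on the smallness of the change, a single fluorine removed with no ring, no donor and no acceptor touched. The step from compound 1 to compound 4 is expected to be modest, a 1.6-fold higher number from compound 1 to compound 4 (0.20 log units; within the scatter), pointing toward a somewhat higher number but likely within the scatter. Compound 4 is therefore estimated to give 16 nM in this assay, with a plausible range from 5 nM to 50 nM.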

Compound 4, half-maximal inhibitory concentration: 2 nM
For compound 4 the middle estimate is 8.0-fold (0.90 log units) above the measured one; the measured number lies below the stated range.
By their numbers in this assay, from the lowest: compound 4; then compounds 1 and 3 (each within the scatter of the next). At a limit, above all of these: compound 2.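

Hydrogen in place of fluoro on this aromatic carbon, ortho to a large group, gives a 5.0-fold lower number from compound 1 to compound 4 (0.70 log units; beyond the scatter) in this assay. This is the first step shown that changes only one place, and it reveals that this position matters: removing one heavy atom, with no ring and no hydrogen-bond donor or acceptor involved, moves the number beyond the scatter, and the fluorine proves unnecessary for strong inhibition in this series. Nothing measured here explains why the lower number comes with the loss of the fluorine.

Only fluoro and hydrogen are shown at this position, so it remains open whether a chlorine atom, a methyl group or a methoxy group there would give a number lower or higher than that of compound 4. This is also a single pair of compounds, which leaves open whether the same change would give a similar step on a different amine ring or with fluoro placed elsewhere on the 2-fluorophenyl ring.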